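From Methylthiophene to a Dimethylphenyl Ring

The source may report more compounds than this note shows. Statements on the series, on what has been measured and on what is new or still open speak of the compounds shown alone.

Among the measured compounds shown here, in a functional assay on DU-145 cells (Homo sapiens) for inhibition, read by trypan blue exclusion, with a stated time of 96 h (on this read-out higher numbers stand for weaker inhibition of growth and lower numbers for stronger inhibition of growth), compound 2 (`Cc1ccc(/C=C(/SCc2ccc(Cl)cc2)C(=O)c2ccc(Cl)cc2)s1`) gives 50000 nM, the higher of the two numbers so far, while compound 1 (`O=C(/C(=C\c1ccc(Br)cc1)SCc1ccc(Cl)cc1)c1ccc(Cl)cc1`) gives 1000 nM. Compound 3 (`Cc1ccc(C)c(/C=C(/SCc2ccc(Cl)cc2)C(=O)c2ccc(Cl)cc2)c1`) carries 2,5-dimethylphenyl in place of 5-methylthiophen-2-yl on a double-bonded chain carbon bound to a double-bonded chain carbon. For the measured compounds named here, one measured step bears on this change: the large 50-fold higher number from compound 1 to compound 2 (1.70 log units; beyond the scatter), which replaced 4-bromophenyl with 5-methylthiophen-2-yl. A substantial partial return towards the lower number is therefore expected, giving an estimated 10-fold lower number from compound 2 to compound 3 (1.00 log units; beyond the scatter). Compound 3 is estimated at 5000 nM, with an expected range of 900 nM to 30000 nM.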

Compound 3, concentration for 50% growth inhibition: 10000 nM
Compound 3: the middle estimate sits 2.0-fold (0.30 log units) below what was measured; measured number inside the range.
By their numbers in this assay, from the lowest: compound 1; then compound 3; then compound 2.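

In this assay, a six-membered aromatic ring of carbon only at this place gives back part of the ground lost with 5-methylthiophen-2-yl (a 5.0-fold lower number from compound 2 to compound 3 (0.70 log units; beyond the scatter)). It still falls short of 4-bromophenyl (a 10-fold higher number from compound 1 to compound 3 (1.00 log units; beyond the scatter)), so swapping the thiophene for a benzene ring does not by itself restore the number of compound 1. Nothing available explains these differences.

On these data alone, whether the bromine itself accounts for the lower number of compound 1 stays open, and so does how a pyridine ring or a phenyl ring bearing an amine would read at this place.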